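Clearance notes on the step from compound 1 to compound 3

This account rests on a few compounds, and the source may have more. Where it says the series, first, only, none or still open, it means among the compounds named here.

Measured so far in an ADME assay on microsomes from liver (Homo sapiens) for metabolic stability, read by LC-MS, tested at 1 uM (a higher number here means faster removal of the compound, a lower number slower removal), for this series:
- compound 1 `OC1(COc2ccc([C@H]3CC[C@]4(CC3)OOC3(O4)C4CC5CC(C4)CC3C5)cc2)CCNCC1` gives 16 mL.min-1.g-1
- compound 2 `CS(=O)(=O)N1CCN(CCCOc2ccc([C@H]3CC[C@]4(CC3)OOC3(O4)C4CC5CC(C4)CC3C5)cc2)CC1` gives 68 mL.min-1.g-1

Compound 1 holds the lower of the two numbers. Compound 3 `N[C@H]1CC[C@@H](Oc2ccc([C@H]3CC[C@]4(CC3)OOC3(O4)C4CC5CC(C4)CC3C5)cc2)CC1` has not been measured, and its change from compound 1 is 4-aminocyclohexyl in place of (4-hydroxypiperidin-4-yl)methyl on an oxygen on an aromatic ring on the same core. Going by the values given here, the one measured step, a 4.3-fold higher number from compound 1 to compound 2 (0.63 log units; beyond the scatter) with a modest size, replaces a different group, so it bears only loosely and no measured step covers 4-aminocyclohexyl. A small rise is therefore expected in this assay with the estimated step being a 1.5-fold higher number from compound 1 to compound 3 (0.18 log units; within the scatter) at most a tentative call. For compound 3 the estimate is 24 mL.min-1.g-1 with an expected range of 10 mL.min-1.g-1 to 60 mL.min-1.g-1 in this read-out.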

Compound 3, intrinsic clearance in microsomes: < 7 mL.min-1.g-1
Compound 3 was reported as a limit (the forecaster's own chance of this, stated with the estimate: 5%); at least 3.4-fold (0.53 log units) between middle value and limit.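

At this position, on an oxygen on an aromatic ring, 4-aminocyclohexyl in place of (4-hydroxypiperidin-4-yl)methyl moves the number in this assay downward, with an at least 2.2-fold lower number from compound 1 to compound 3 (0.35 log units; beyond the scatter). Together with a 4.3-fold higher number from compound 1 to compound 2 (0.63 log units; beyond the scatter), changes at this position on the shared core now move the number in both directions. Compound 3 gives < 7 mL.min-1.g-1, which is a limit and not a number, so the full size of its step stays open: the limit of < 7 mL.min-1.g-1 in this assay, at which 1 of the 3 values shown sits.

On these data alone, whether the amine or the carbon ring of 4-aminocyclohexyl goes with the lower number remains open. A plain cyclohexyl or a 4-hydroxycyclohexyl on the same oxygen would separate the two.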